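From fluoro to carboxy on a shared core

The source may report more compounds than this note shows. Statements on the series, on what has been measured and on what is new or still open speak of the compounds shown alone.

Of the compounds shown here, three built on one shared core have so far been tested in a physicochemical assay, read by spectrophotometry, with a stated time of 10 min; a higher number here means a weaker inhibitor, a lower number a stronger inhibitor. Compound 1 `O=c1cc(-c2ccccc2)oc2cc(OCCCCNc3nc4ccccc4s3)cc(O)c12` gives 8.57 ug/mL. Compound 2 `O=c1cc(-c2ccccc2)oc2cc(OCCCCNc3nc4ccc(I)cc4s3)cc(O)c12`, which carries iodo in place of hydrogen on an aromatic carbon, gives 9.84 ug/mL. Compound 3 `O=c1cc(-c2ccccc2)oc2cc(OCCCCNc3nc4ccc(F)cc4s3)cc(O)c12`, which instead carries fluoro in place of hydrogen on an aromatic carbon, gives 5.25 ug/mL.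

Compound 3 stands at the lowest of the three numbers, but the gaps are small: a 1.6-fold lower number from compound 1 to compound 3 (0.21 log units; within the scatter), a 1.9-fold lower number from compound 2 to compound 3 (0.27 log units; within the scatter), and a 1.1-fold higher number from compound 1 to compound 2 (0.06 log units; within the scatter). None of the three compounds can therefore be set apart from the others on this evidence.

Compound 4 `O=C(O)c1ccc2nc(NCCCCOc3cc(O)c4c(=O)cc(-c5ccccc5)oc4c3)sc2c1` has not yet been measured. It differs from compound 3 in one place: carboxy in place of fluoro on an aromatic carbon. Within the data shown here, no measured step involves a carboxy group, so the only guide is that exchanging hydrogen, iodo and fluoro at this aromatic carbon left this assay essentially unchanged. On that basis compound 4 is expected to show a 1.3-fold higher number from compound 3 to compound 4 (0.12 log units; within the scatter), a step not beyond the scatter. The estimate for compound 4 is 7 ug/mL, with a range from 3.5 ug/mL to 14 ug/mL.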

Compound 4, half-maximal inhibitory concentration: 6.74 ug/mL
Compound 4: middle estimate off by 1.0-fold (0.02 log units), on the high side, within the range that was stated.
By their numbers in this assay, from the lowest: compounds 3, 4, 1 and 2 (each within the scatter of the next).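

In this assay, carboxy differs from the earlier groups at this aromatic carbon in being larger than fluoro, with 3 heavy atoms against 1, and in bringing a hydrogen-bond donor and a hydrogen-bond acceptor that fluoro lacks, yet the result is a 1.3-fold higher number from compound 3 to compound 4 (0.11 log units; within the scatter), alongside a 1.5-fold lower number from compound 2 to compound 4 (0.16 log units; within the scatter) and a 1.3-fold lower number from compound 1 to compound 4 (0.10 log units; within the scatter). The earlier compounds shown here covered only hydrogen, iodo and fluoro at this carbon, whereas the 6-carboxy-1,3-benzothiazol-2-yl group shows that a quite different kind of substituent can also sit there without a step that stands out from the scatter, so none of the four compounds can be set apart from the others. Nothing available here explains this lack of separation between the compounds.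

Going by these compounds, it remains open whether an amine, a methyl ester or an amide at this same carbon would also stay within the scatter of compound 4 or would at last produce a clear step. On these data alone, it is also open whether a longer chain between the shared core and the 1,3-benzothiazol-2-yl group would change the number in this assay more than any substituent at this carbon has done.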